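A few compounds are considered here, and "the series" means these few. Any claim that something is new, unique, unknown or untested is made for them only; others in the source may bear on it.

Compound 1, `O=C(NCCCCCCCn1cc(-c2ccc[n+]([O-])c2)nn1)c1ccccc1-c1ccccc1`, in an ADME assay on SH-SY5Y cells (Homo sapiens) for cytotoxicity, read by MTT assay, with a stated time of 48 h; on this read-out lower numbers stand for an effect already at smaller amounts and higher numbers for an effect only at larger amounts of compound: "not determined" (no result reported).
Compound 2, `O=C(O)c1ccccc1-c1ccccc1C(=O)NCCCCCCCn1cc(-c2cccnc2)nn1`, in this assay: the limit > 500 nM.
Compound 3, `O=C(O)c1cccc(-c2ccccc2C(=O)NCCCCCCCn2cc(-c3cccnc3)nn2)c1`, in this assay: the limit > 500 nM.

Compound 3 therefore stands not at a number but at the edge of what this assay can report; it shares this position with compound 2, as the limit of > 500 nM in this assay, at which 2 of the 3 values shown sit, shows, while compound 1 has no result at all. Going by the values given here, the only measured step between neighbours, a step that the two limits leave unreadable from compound 2 to compound 3, is consequently unreadable in size, since both of its ends are limits.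

Compound 4, `O=C(NCCCCCCCn1cc(-c2cccnc2)nn1)c1ccccc1-c1cccnc1`, is the next compound to be measured. It differs from compound 3 by pyridin-3-yl in place of 3-carboxyphenyl on an aromatic carbon. Among the compounds with values here, no measured step bears on this change in a readable way: the one step available tells nothing about its direction or size, and the two measured values only show that neither compound reached an effect within the tested range.

On that basis compound 4 is expected to behave like compound 3 and to sit at or beyond the same limit, so the estimate for compound 4 is 2000 nM, with a range from 500 nM to 10000 nM. The step that the limit leaves unreadable from compound 3 to compound 4 that this estimate implies is expected to stay within the usual scatter.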

Compound 4, half-maximal effective concentration: 36.5 nM
Estimate against measurement, compound 4: 55-fold (1.74 log units) above; the measured number lies below the stated range.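

In this assay, going by these compounds alone, the aromatic carbon ortho to a large group proves sensitive to what it carries, which the earlier compounds could not show: pyridin-3-yl in place of 3-carboxyphenyl gives an at least 13-fold lower number from compound 3 to compound 4 (1.13 log units; beyond the scatter), and pyridin-3-yl in place of 2-carboxyphenyl gives an at least 13-fold lower number from compound 2 to compound 4 (1.13 log units; beyond the scatter). Both steps therefore point the same way, towards cytotoxicity at smaller amounts of compound, and each is a minimum size, since it starts from a limit rather than a number. The step between the two carboxyphenyl compounds cannot be read, and compound 2 and compound 3 share a single limit: the limit of > 500 nM in this assay, at which 2 of the 4 values shown sit.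

The compounds shown leave open which part of the change matters, since the carboxylic acid leaves and the ring nitrogen of pyridin-3-yl enters in the same step. As far as these compounds go, it also remains open how an aminophenyl group or the methyl ester of the carboxylic acid would behave on this same aromatic carbon.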